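The source may hold more compounds than are shown below. What is called first, only, known or untested is meant among the compounds shown, and "the series" means these compounds.

Of the compounds shown here, three built on one shared core have been tested in a functional assay on U-251 cells (Homo sapiens) for inhibition, read by sulforhodamine B assay, with a stated time of 48 h; a higher number here means that more compound is tolerated, a lower number that less compound is tolerated. Compound 2 `Nc1cc(N)c2nc(-c3ccccc3)c(NCc3ccc(F)cc3)nc2c1` gives 6310 nM in this assay. Compound 3 `COc1ccc(CNc2nc3cc(N)cc(N)c3nc2-c2ccccc2)cc1` gives 51300 nM, and the step of an 8.1-fold higher number from compound 2 to compound 3 (0.91 log units; beyond the scatter) is the only one among the three whose size can be read. Compound 1 `Nc1cc(N)c2nc(-c3ccccc3)c(NCc3ccc(Cl)c(Cl)c3)nc2c1` gives < 100000 nM, which is a limit of the assay and not a number. The steps a step that the limit leaves unreadable from compound 1 to compound 2 and a step that the limit leaves unreadable from compound 1 to compound 3 therefore have no readable size (the limit of < 100000 nM in this assay, at which 1 of the 3 values shown sits). Among the two numbers, compound 2 stands lowest, with compound 3 as its nearest neighbour.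

Compound 4 `Nc1cc(N)c2nc(-c3ccccc3)c(Sc3ccc(F)cc3)nc2c1` has not yet been measured. It differs from compound 2 by (4-fluorophenyl)sulfanyl in place of (4-fluorobenzyl)amino on an aromatic carbon. For the measured compounds named here, none of the measured steps changes the link between the core and the fluorinated ring; the only readable step, an 8.1-fold higher number from compound 2 to compound 3 (0.91 log units; beyond the scatter), exchanges one ring substituent for another. That step shows how far a change within this group can move the number, but it gives no direction for the present change, so a shift of comparable size either way remains possible. The expected step is a modest rise, a 2.2-fold higher number from compound 2 to compound 4 (0.35 log units; beyond the scatter). Compound 4 is accordingly estimated at 14000 nM, within a range from 3500 nM to 56000 nM.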

Compound 4, concentration lethal to 50% of the cells: 61700 nM
Beside the measured number, compound 4's estimate is 4.4-fold (0.64 log units) below it; the whole stated range lies below it.
By their numbers in this assay, from the lowest: compound 2; then compounds 3 and 4 (each within the scatter of the next).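

For the compounds shown here, compounds 1, 2 and 3 differ only in the groups on the outer ring, whereas compound 4 is the first to change the link between that ring and the shared core, at the aromatic carbon next to the ring nitrogen. In this assay this swap of (4-fluorobenzyl)amino for (4-fluorophenyl)sulfanyl gives a 9.8-fold higher number from compound 2 to compound 4 (0.99 log units; beyond the scatter) even though the fluorinated ring stays the same, so the ring alone does not hold the number at the level of compound 2 and the link counts too. The swap replaces nitrogen with sulfur, removes the chain carbon and loses the hydrogen-bond donor all at once, and nothing measured here shows which of these changes matters or why.

The compounds shown leave open how the step divides between the atom in the link and the chain carbon, which (4-fluorobenzyl)sulfanyl and (4-fluorophenyl)amino would help to separate. They also leave open whether the methoxy group moves the number the same way on a sulfur link, as (4-methoxyphenyl)sulfanyl would show.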